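Fluoro to Chloro on the Phenyl of Compound 2

This account rests on a few compounds, and the source may have more. Where it says the series, first, only, none or still open, it means among the compounds named here.

Going by the values given here, compound 2 `O=[N+]([O-])c1ccc(N/C(=N\O)c2ccccc2F)c2nonc12` gives 63 nM in an assay on isolated protein for inhibition of Indoleamine 2,3-dioxygenase 1 (Homo sapiens), read by spectrophotometry, with a stated time of 1 h (on this read-out higher numbers stand for weaker inhibition and lower numbers for stronger inhibition), the lowest of the two numbers so far; compound 1 `O=[N+]([O-])c1ccc(N/C(=N\O)c2ccccc2)c2nonc12` gives 268 nM, and the step of a 4.3-fold lower number from compound 1 to compound 2 (0.63 log units; beyond the scatter) lies beyond the scatter. Compound 3 `O=[N+]([O-])c1ccc(N/C(=N\O)c2ccccc2Cl)c2nonc12` differs from compound 2 by chloro in place of fluoro on an aromatic carbon. Among the compounds with values here, no measured step exchanges one halogen for another; the only step at hand, a 4.3-fold lower number from compound 1 to compound 2 (0.63 log units; beyond the scatter), concerns adding a halogen where hydrogen stood. Compound 3 is therefore expected to show a step no larger than the scatter, a 1.3-fold lower number from compound 2 to compound 3 (0.10 log units; within the scatter). Compound 3 is estimated at 50 nM, with a range of 20 nM to 150 nM.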

Compound 3, half-maximal inhibitory concentration: 135 nM
Compound 3: middle estimate off by 2.7-fold (0.43 log units), on the low side; measured number inside the range.
By their numbers in this assay, from the lowest: compound 2; then compounds 3 and 1 (each within the scatter of the next).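

Which halogen stands on this aromatic carbon matters: exchanging fluoro for chloro gives a step beyond the scatter (a 2.1-fold higher number from compound 2 to compound 3 (0.33 log units; beyond the scatter)), so what fluoro gave over hydrogen does not carry over in full to chloro. Chloro in place of hydrogen gives a step that stays within the scatter (a 2.0-fold lower number from compound 1 to compound 3 (0.30 log units; within the scatter)), which leaves only fluoro clearly apart from hydrogen here. Nothing given here accounts for the difference between the two halogens. The compounds shown leave open whether bromo, methyl or methoxy on this carbon would stand nearer compound 2 or compound 1.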